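This account rests on a few compounds, and the source may have more. Where it says the series, first, only, none or still open, it means among the compounds named here.

Measured in an ADME assay on BJ cells (Homo sapiens) for cytotoxicity, read by luminescence, with a stated time of 72 h; on this read-out lower numbers stand for an effect already at smaller amounts and higher numbers for an effect only at larger amounts of compound:

Compound 1 `CCOC(=O)c1c(-c2cc(F)cc(OC)c2)[nH]c2cc(OC)ccc2c1=O`: > 21500 nM
Compound 2 `CCCCOc1cccc(-c2[nH]c3cc(OC)ccc3c(=O)c2C(=O)OCC)c1`: > 21500 nM
Compound 3 `CCOC(=O)c1c(-c2cccc(Cl)c2)[nH]c2cc(OC)ccc2c1=O`: > 21500 nM

Each of these three entries is a limit of the assay and not a number, so the series offers no measured value to rank. All three compounds sit together at the limit of > 21500 nM in this assay, at which 3 of the 3 values shown sit. Compound 3 therefore stands only at its limit of > 21500 nM, level with the other two as far as can be told.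

Compound 4 `CCOC(=O)c1c(-c2cccc(Br)c2)[nH]c2cc(OC)ccc2c1=O` has bromo in place of chloro on an aromatic carbon, meta to a large group: bromo in place of chloro on an aromatic carbon. Among the compounds with values here, two measured steps bear on this change, a step that the two limits leave unreadable from compound 1 to compound 3 and a step that the two limits leave unreadable from compound 2 to compound 3. With neither of them readable, no step beyond the scatter is expected in this assay, in either direction. The expected change is a step that the limit leaves unreadable from compound 3 to compound 4. Another report of a limit is the likeliest outcome. For compound 4 the estimated value is 25000 nM, with an expected range from 12000 nM to 50000 nM.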

Compound 4, half-maximal effective concentration: > 21500 nM
Compound 4 was reported as a limit; the forecaster's own chance of this, stated with the estimate: 85%; the middle value does not contradict the limit.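

In this assay compound 4 gives > 21500 nM, which is a limit of the assay and not a number. Its steps from compound 1, compound 2 and compound 3 therefore cannot be read. The compounds shown leave open at what concentration, if any, each would reach a half-maximal effect.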